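The source may hold more compounds than are shown below. What is called first, only, known or untested is meant among the compounds shown, and "the series" means these compounds.

In a functional assay on HCT-116 cells (Homo sapiens) for inhibition, read by MTT assay, with a stated time of 24 h, tested at 10 uM (a higher number here means more inhibition of growth at the concentration tested, a lower number less inhibition of growth), compound 2 `N#Cc1ccc(-c2cnc3[nH]cc(-c4nnc(-c5ccc(Cl)cc5)o4)c(=O)c3c2)cc1` gives 18.3%. Its only comparator, compound 1 `N#Cc1ccc(-c2cnc3[nH]cc(-c4nnc(-c5ccc(F)cc5)o4)c(=O)c3c2)cc1`, gives 18.9% in this assay, and the step of a number 0.6 percentage points lower from compound 1 to compound 2 (within the scatter) is within the scatter, so the two compounds read alike. Compound 3 `O=c1c(-c2nnc(-c3ccc(Cl)cc3)o2)c[nH]c2ncc(-c3ccccc3)cc12` differs from compound 2 by hydrogen in place of cyano on an aromatic carbon, para to a large group. Among the compounds with values here, no measured step bears on that position; the only step recorded, a number 0.6 percentage points lower from compound 1 to compound 2 (within the scatter), concerns the other aryl group and was small. Compound 3 is therefore expected to show a step of a number 2.3 percentage points lower from compound 2 to compound 3 (within the scatter) that stays within the scatter, estimated at 16% with a range of 2% to 32%.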

Compound 3, percent growth inhibition at one concentration: 21.6%
The estimate for compound 3 lay 5.6 percentage points below the measured number; low and high end bracket the measured number.
By their numbers in this assay, from the lowest: compounds 2, 1 and 3 (each within the scatter of the next).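

In this assay the change from 4-cyanophenyl to phenyl gives a number 3.3 percentage points higher from compound 2 to compound 3 (within the scatter) and so the two compounds read alike. Within the data shown here, the nitrile on this aromatic carbon, para to a large group, is therefore not needed for this level of growth inhibition, something the earlier compounds, which differ only on the other aryl group, could not show. What the compounds shown leave open is whether another group at this place, such as an amine or a carboxylic acid, would shift the reading beyond the scatter. No measurement is at hand that would explain the result.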